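The compounds below may be only part of what the source reports. "The series", "measured", "known", "first", "only" and "open" are said of these compounds alone.

Compound 1 `Cn1nnnc1SCC(=O)N/N=C/c1ccc(Cl)cc1` carries chloro on an aromatic carbon of a six-membered aromatic ring of carbon only, para to a large group. In a functional assay on A549 cells (Homo sapiens) for cytotoxicity, read by XTT assay, with a stated time of 24 h (on this read-out higher numbers stand for weaker inhibition and lower numbers for stronger inhibition), compound 1 gives 100000 nM. Compound 2 `Cn1nnnc1SCC(=O)N/N=C/c1ccc(Br)cc1` differs from it by one change (bromo in place of chloro on an aromatic carbon). In this assay compound 2 gives > 10000000 nM, which is a limit of the assay rather than a number, (the limit of > 10000000 nM in this assay, at which 1 of the 3 values shown sits). That pair shows an at least 100-fold higher number from compound 1 to compound 2 (2.00 log units; beyond the scatter). Compound 3 `Cn1nnnc1SCC(=O)N/N=C/c1ccccc1Cl` has the same atoms as compound 1, joined differently; the difference between the two cores is not broken down here. In this assay compound 3 gives 6320000 nM. Compound 4 `Cn1nnnc1SCC(=O)N/N=C/c1ccccc1Br` differs from compound 3 by bromo in place of chloro on an aromatic carbon. This is the same kind of change as from compound 1 to compound 2, but the place differs: ortho to a large group rather than para. A step of similar direction and size is expected. Compound 4 is therefore estimated at 40000000 nM, with a range from 8000000 nM to 300000000 nM. That estimate means an expected step of a 6.3-fold higher number from compound 3 to compound 4 (0.80 log units; beyond the scatter), resting on the measured step of an at least 100-fold higher number from compound 1 to compound 2 (2.00 log units; beyond the scatter).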

Compound 4, half-maximal inhibitory concentration: 2000000 nM
Compound 4: middle estimate off by 20-fold (1.30 log units), on the high side, and the stated range ends above it.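

Bromo in place of chloro on an aromatic carbon gives a 3.2-fold lower number from compound 3 to compound 4 (0.50 log units; beyond the scatter) in this assay, the opposite direction to the earlier at least 100-fold higher number from compound 1 to compound 2 (2.00 log units; beyond the scatter), so the step measured on one core did not carry over to the other: the same change on two cores in this assay, an at least 100-fold higher number (2.00 log units; beyond the scatter) from compound 1 to compound 2 and a 3.2-fold lower number (0.50 log units; beyond the scatter) from compound 3 to compound 4, at least 310-fold (2.49 log units) apart, beyond the scatter of two such steps

Compound 2 gives > 10000000 nM, which is a limit of the assay and not a number: the limit of > 10000000 nM in this assay, at which 1 of the 4 values shown sits.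

Together these two pairs show that, among these four compounds, the same swap cannot be assumed to act alike on both cores, but they do not show why the steps part ways, nor which of them a further core would follow.

The compounds shown carry only chloro or bromo on the aromatic ring, so it remains open how a fluoro group, a methoxy group or an amine in the same place would read in this assay. Also open, as far as these compounds go, is whether the swap would follow either step on a core bearing a longer chain.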